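Swapping the aryl on the ring nitrogen: compound 3 to compound 4

The compounds below may be only part of what the source reports. "The series", "measured", "known", "first", "only" and "open" are said of these compounds alone.

Of the compounds shown here, three that share one core have been measured in a functional assay on PC-12 cells (Rattus norvegicus) for cytotoxicity, read by MTT assay, with stated times of 2 h and 24 h, tested at 10 uM; on this read-out lower numbers stand for a weaker effect and higher numbers for a stronger effect at the one concentration tested. Compound 1 `Cc1ccc(-n2nc(-c3ccc(C(F)(F)F)cc3O)nc2-c2ccccc2O)cc1` gives 102%, compound 2 `Oc1cc(C(F)(F)F)ccc1-c1nc(-c2ccccc2O)n(-c2ccc(I)cc2)n1` gives 105%, and compound 3 `COc1ccc(-n2nc(-c3ccc(C(F)(F)F)cc3O)nc2-c2ccccc2O)cc1` gives 98.9%. Compound 3 holds the lowest of the three numbers, yet every step among them stays within the scatter: a number 3 percentage points higher from compound 1 to compound 2 (within the scatter), a number 3.1 percentage points lower from compound 1 to compound 3 (within the scatter) and a number 6.1 percentage points lower from compound 2 to compound 3 (within the scatter). All three compounds therefore stand together at essentially full activity on this read-out.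

Compound 4 `Oc1cc(C(F)(F)F)ccc1-c1nc(-c2ccccc2O)n(-c2cccc(Cl)c2)n1` differs from compound 3 in one place: 3-chlorophenyl in place of 4-methoxyphenyl on an aromatic nitrogen. The measured steps that bear on this change are the two in which a group on the aryl attached to the ring nitrogen was exchanged, a number 3.1 percentage points lower from compound 1 to compound 3 (within the scatter) and a number 6.1 percentage points lower from compound 2 to compound 3 (within the scatter), both within the scatter. Nothing in these data suggests that exchanging the group on this aryl moves the number in this assay beyond the scatter, so no change in either direction beyond the scatter is expected.

Compound 4 is therefore estimated to give 101% in this assay, with a range from 90% to 112%, which corresponds to an expected step of a number 2.1 percentage points higher from compound 3 to compound 4 (within the scatter).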

Compound 4, a percentage reported as activity, at one concentration (the size of the read-out at that concentration, not a potency): 100%
Compound 4: middle estimate off by 1 percentage points, on the high side; the range from low to high includes it.
By their numbers in this assay, from the lowest: compounds 3, 4, 1 and 2 (each within the scatter of the next).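

Until now the aryl on the aromatic nitrogen had been 4-methylphenyl, 4-iodophenyl or 4-methoxyphenyl, and compound 4 brings in a different group at a different place on that aryl, a 3-chlorophenyl. Even so, this assay gives a number 1.1 percentage points higher from compound 3 to compound 4 (within the scatter) and also a number 5 percentage points lower from compound 2 to compound 4 (within the scatter) and a number 2 percentage points lower from compound 1 to compound 4 (within the scatter) so that the new group stands level with all three earlier ones. The oxygen of the methoxy group is thus not needed to hold the number on this read-out, and neither is a group in the 4-position of this aryl, at least for these four compounds at the one concentration tested, while nothing given here offers an explanation for this flat picture.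

On these data alone, all four compounds carry a neutral, halogen, alkyl or ether-bearing phenyl at this position, so it remains open whether an amine or a carboxylic acid on the aryl, or a longer chain in place of the aryl, would move the number beyond the scatter. Also open, as far as these compounds go, is whether the two hydroxyl groups and the trifluoromethyl group of the shared core matter to this read-out, since they stay the same throughout.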